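This account rests on a few compounds, and the source may have more. Where it says the series, first, only, none or still open, it means among the compounds named here.

The measured compounds:
compound 1 `COc1nc(N)nc2c1c(-c1ccccc1)cn2[C@@H]1O[C@H](CO)[C@@H](O)[C@H]1O` gives > 20000 nM
compound 2 `COc1ncnc2c1c(-c1cccs1)cn2[C@@H]1O[C@H](CO)[C@@H](O)[C@H]1O` gives 90 nM
compound 3 `COc1nc(N)nc2c1c(-c1cccs1)cn2[C@@H]1O[C@H](CO)[C@@H](O)[C@H]1O` gives > 20000 nM

Going by the values given here, in a functional assay on CCRF-CEM cells (Homo sapiens), read by MTT assay, with a stated time of 72 h (on this read-out higher numbers stand for weaker inhibition and lower numbers for stronger inhibition), compound 2 gives 90 nM, the only number among the three values shown. For compound 3 this assay reports only a limit, > 20000 nM. For compound 1 it likewise reports only a limit, > 20000 nM. Compound 2 and compound 3 share everything but the change (hydrogen in place of amino on an aromatic carbon), and the step of an at least 220-fold higher number from compound 2 to compound 3 (2.34 log units; beyond the scatter). Between compound 3 and compound 1 the change is phenyl in place of thiophen-2-yl on an aromatic carbon; the step that the two limits leave unreadable from compound 3 to compound 1 because both values sit at the limit of > 20000 nM in this assay, at which 2 of the 3 values shown sit.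

Compound 4 `COc1ncnc2c1c(-c1ccccc1)cn2[C@@H]1O[C@H](CO)[C@@H](O)[C@H]1O` has not yet been measured in this assay. It differs from compound 2 by phenyl in place of thiophen-2-yl on an aromatic carbon, the same change as from compound 3 to compound 1, in the same place. That earlier step gives no readable size, so the expectation for compound 4 rests on compound 2 alone and on the observation that the same change left compound 1 and compound 3 both at the limit, which neither supports nor rules out a change. He expects the step of a 2.8-fold higher number from compound 2 to compound 4 (0.44 log units; beyond the scatter) to be modest. His estimate for compound 4 is 250 nM, between 50 nM and 3000 nM.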

Compound 4, half-maximal inhibitory concentration: > 20000 nM
Compound 4 gave a limit, no number; the forecaster's own chance of this, stated with the estimate: 10%; middle value at least 80-fold (1.90 log units) from the limit.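

As far as these compounds go, on the core without the amino group, phenyl in place of thiophen-2-yl brings in this assay an at least 220-fold higher number from compound 2 to compound 4 (2.34 log units; beyond the scatter), a large step whose true size stays open, as the value of compound 4 is only a limit. The same change on the core with the amino group cannot be read, and neither can the step between compound 1 and compound 4, because in each pair both values sit at one point: the limit of > 20000 nM in this assay, at which 3 of the 4 values shown sit. The result therefore shows what this change does on one core only; it does not show that the change carries over to the other core, where compound 3 and compound 1 give limits and no numbers.

With compound 2 the only compound that gives a number, the compounds shown leave open how far activity depends on thiophen-2-yl itself. They also leave open how an amine, a methyl group or a longer alkyl chain would read on that same aromatic carbon in this assay.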